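Ester in place of the basic amide on the shared core

This account rests on a few compounds, and the source may have more. Where it says the series, first, only, none or still open, it means among the compounds named here.

Compound 3 `CCN(CC)CCCNC(=O)c1ccc(C(CC)(CC)c2ccc(OCC(=O)C(C)(C)C)c(C)c2)n1CC` gives 22 nM in an assay on HL-60 cells for agonist activity at vitamin D3 receptor (Homo sapiens), read by microscopy, with a stated time of 96 h (a higher number here means that more compound is needed for the effect, a lower number that less compound is needed), the lowest of the two numbers, with compound 1 `CC[C@@H](C)[C@H](NC(=O)c1ccc(C(CC)(CC)c2ccc(OCC(=O)C(C)(C)C)c(C)c2)n1CC)C(=O)OC` at 590 nM. Compound 2 `CCOC(=O)CN(C)C(=O)c1ccc(C(CC)(CC)c2ccc(OCC(=O)C(C)(C)C)c(C)c2)n1CC` returns only a limit in this assay, > 50000 nM. The measured steps on the carbonyl substituent are all large: a 27-fold lower number from compound 1 to compound 3 (1.43 log units; beyond the scatter), an at least 84-fold higher number from compound 1 to compound 2 (1.92 log units; beyond the scatter) and an at least 2200-fold lower number from compound 2 to compound 3 (3.35 log units; beyond the scatter). Compound 4 `C#CC(C)OC(=O)c1ccc(C(CC)(CC)c2ccc(OCC(=O)C(C)(C)C)c(C)c2)n1CC` differs from compound 3 by (1-methylprop-2-yn-1-yl)oxy in place of (3-(diethylamino)propyl)amino on a carbonyl carbon. For the measured compounds named here, the group that accompanied the lowest number leaves, and the only changes at this position so far moved the number by large amounts, so a large rise beyond the scatter is expected for compound 4, a 110-fold higher number from compound 3 to compound 4 (2.06 log units; beyond the scatter). The estimate for compound 4 is 2500 nM, within 250 nM to 30000 nM.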

Compound 4, half-maximal effective concentration: 210 nM
Compound 4: the middle estimate sits 12-fold (1.08 log units) above what was measured; measured number below the stated range.
By their numbers in this assay, from the lowest: compound 3; then compound 4; then compound 1. At a limit, above all of these: compound 2.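

On the carbonyl carbon, a nitrogen link is not required for a value in this range: (1-methylprop-2-yn-1-yl)oxy in place of (3-(diethylamino)propyl)amino gives only a 9.5-fold higher number from compound 3 to compound 4 (0.98 log units; beyond the scatter). The same group also gives a 2.8-fold lower number from compound 1 to compound 4 (0.45 log units; beyond the scatter), so this ester is not ranked below every amide shown. The remaining step, an at least 230-fold lower number from compound 2 to compound 4 (2.37 log units; beyond the scatter), starts from a limit rather than a number: the limit of > 50000 nM in this assay, at which 1 of the 4 values shown sits.

Still open, from the compounds shown here alone, is whether the gap to compound 3 follows the change from amide to ester or the loss of the diethylamino group. A 3-(diethylamino)propyl ester or a 1-methylprop-2-yn-1-yl amide would separate the two.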